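From 3-chlorophenyl to 4-bromophenyl in a flat series

A few compounds are considered here, and "the series" means these few. Any claim that something is new, unique, unknown or untested is made for them only; others in the source may bear on it.

Of the compounds shown here, three with a shared core have been tested in a functional assay on HepG2 cells (Homo sapiens) for cytotoxicity, read by MTT assay, with a stated time of 72 h; on this read-out higher numbers stand for weaker inhibition and lower numbers for stronger inhibition. Compound 1 `CN1CCN(c2ccc(Nc3ncc4nc(Nc5cccc([N+](=O)[O-])c5)n(C5CCCC5)c4n3)cc2)CC1` reads > 5000 nM, which is a limit of the assay and not a number. The record holds just this one such reading: the limit of > 5000 nM in this assay, at which 1 of the 3 values shown sits. Compound 2 `C#Cc1cccc(Nc2nc3cnc(Nc4ccc(N5CCN(C)CC5)cc4)nc3n2C2CCCC2)c1` gives 4900 nM. Compound 3 `CN1CCN(c2ccc(Nc3ncc4nc(Nc5cccc(Cl)c5)n(C5CCCC5)c4n3)cc2)CC1` gives 4800 nM, which places it level with compound 2 within the scatter.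

Compound 4 `CN1CCN(c2ccc(Nc3ncc4nc(Nc5ccc(Br)cc5)n(C5CCCC5)c4n3)cc2)CC1` has 4-bromophenyl in place of 3-chlorophenyl on a nitrogen on an aromatic ring. The nearest evidence comes from exchanging one group on an aromatic carbon. The step of a 1.0-fold lower number from compound 2 to compound 3 (0.01 log units; within the scatter) lies within the scatter. The steps of an at least 1.0-fold lower number from compound 1 to compound 2 (0.00 log units; that floor lies within the scatter) and an at least 1.0-fold lower number from compound 1 to compound 3 (0.01 log units; that floor lies within the scatter) are only floors, and both floors also lie within the scatter. None of these steps brings in bromine, so they offer only indirect guidance.

Since all three steps remain within the scatter, the expected result in this assay is no change beyond it, with no favoured direction: no change at the digits printed from compound 3 to compound 4 (within the scatter). The estimated value for compound 4 is 4800 nM, with an expected range from 2400 nM to 8000 nM.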

Compound 4, half-maximal inhibitory concentration: > 5000 nM
Compound 4 gave a limit, no number; the forecaster's own chance of this, stated with the estimate: 40%; at least 1.0-fold (0.01 log units) between middle value and limit.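

Unlike the earlier steps, this one brings in bromine and moves the halogen at the same time, and in this assay it gives an at least 1.0-fold higher number from compound 3 to compound 4 (0.01 log units; that floor lies within the scatter), so even this larger change of the phenyl group on that nitrogen shows no shift that can be told from the scatter. Going by these compounds, the comparison with the ethynyl compound reads the same way, with an at least 1.0-fold higher number from compound 2 to compound 4 (0.00 log units; that floor lies within the scatter), and both figures are only floors, so the true size of either step is unknown. The reading for compound 4 is a limit and not a number, and compound 1 carries the same limit, so the step between those two cannot be read: the limit of > 5000 nM in this assay, at which 2 of the 4 values shown sit.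

The compounds shown do not separate the change of halogen from the change in where it sits on the phenyl ring, so neither can be judged alone. On these data alone, whether a phenyl ring carrying an amine or a carboxylic acid would give a number clearly lower than that of compound 3 also remains open.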